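Swapping a Thiophene for a Pyridine on the Shared Core

This account rests on a few compounds, and the source may have more. Where it says the series, first, only, none or still open, it means among the compounds named here.

Compound 1 `COC(=O)C1=C(C)NC(C)=C(C(=O)OC)C1c1c(-c2cccs2)nc2sccn12` is a dihydropyridine diester that carries a fused two-ring system, and on that system a thiophen-2-yl group. For the measured compounds named here, in a functional assay on ileum (Cavia porcellus) for inhibition (a lower number here means a stronger inhibitor, a higher number a weaker inhibitor), compound 1 gives 110 nM, the lowest of the two numbers known here. Compound 2 `COC(=O)C1=C(C)NC(C)=C(C(=O)OC)C1c1c(-c2cccs2)nc2sc(C)cn12` differs only by a methyl in place of a hydrogen on an aromatic carbon of the fused system; in this assay compound 2 gives 1370 nM, and the step is a 12-fold higher number from compound 1 to compound 2 (1.10 log units; beyond the scatter).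

Compound 3 `COC(=O)C1=C(C)NC(C)=C(C(=O)OC)C1c1c(-c2ccccn2)nc2sccn12` replaces the thiophene of compound 1 with a pyridine: pyridin-2-yl in place of thiophen-2-yl on an aromatic carbon. Going by the values given here, no measured step touches this position, and the methyl step from compound 1 to compound 2 concerns a different carbon, so it offers no direct guide. Without such a guide, a step within the scatter or a modest one is expected, in either direction. Compound 3 is therefore estimated at 200 nM, within 60 nM to 700 nM, which would mean an expected step of a 1.8-fold higher number from compound 1 to compound 3 (0.26 log units; within the scatter).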

Compound 3, half-maximal inhibitory concentration: 2570 nM
The estimate for compound 3 lay 13-fold (1.11 log units) below the measured number; measured number outside the range, above it.
By their numbers in this assay, from the lowest: compound 1; then compounds 2 and 3 (each within the scatter of the next).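

This carbon of the fused system is sensitive to what it carries: in this assay, pyridin-2-yl in place of thiophen-2-yl gives a 23-fold higher number from compound 1 to compound 3 (1.37 log units; beyond the scatter). The two groups match in some simple counts, each being a single aromatic ring with one hetero atom and one hydrogen-bond acceptor, so those counts alone do not settle the outcome here. They differ in ring size and in the hetero atom, sulfur against nitrogen, and no measurement at hand gives a reason for the step.

Among the compounds shown, this carbon carries only thiophen-2-yl and pyridin-2-yl, so it remains open how a phenyl or furan-2-yl group would read there. A pyridin-3-yl group would show whether moving the ring nitrogen alters the number.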